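Trimethoxyphenyl cyclopropane amides: an anilide versus a benzylamide

This account rests on a few compounds, and the source may have more. Where it says the series, first, only, none or still open, it means among the compounds named here.

Compound 1, `CCOC(=O)C1(C(=O)NCc2ccc(C)cc2)CC1c1cc(OC)c(OC)c(OC)c1`: > 100000 nM; > 100000 nM (2 entries) in a functional assay on K562 cells (Homo sapiens) for cytotoxicity, read by MTT assay, with a stated time of 48 h; on this read-out higher numbers stand for weaker inhibition and lower numbers for stronger inhibition
Compound 2, `CCOC(=O)[C@]1(C(=O)NCc2ccc(C)cc2)C[C@H]1c1cc(OC)c(OC)c(OC)c1`: > 100000 nM in this assay
Compound 3, `CCOC(=O)[C@@]1(C(=O)Nc2ccccc2)C[C@H]1c1cc(OC)c(OC)c(OC)c1`: > 100000 nM in this assay

Each of the three values shown is a limit of the assay and not a number. The value for compound 1 is such a limit, and the compound appears in two entries. The value for compound 2 is also a limit. Compound 3 stands at that same limit, so nothing places it above or below its neighbours; the limit of > 100000 nM in this assay, at which 2 of the 3 values shown sit, is all the numbers show. Compounds 1 and 2 differ only in the way they are drawn, as the fact that one of compounds 1 and 2 is drawn with a defined configuration and the other without, at the place where they differ, and both sit at the limit.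

Compound 4, `CCOC(=O)[C@@]1(C(=O)NCc2ccc(C)cc2)C[C@H]1c1cc(OC)c(OC)c(OC)c1`, has not been measured. Relative to compound 3 it carries 4-methylbenzyl in place of phenyl on an amide-type nitrogen. Among the measured compounds shown here, no step between measured compounds is available for this change. Since compound 3 gives > 100000 nM, and compound 2, which bears the same 4-methylbenzyl amide, also sits at the limit, the expected step of a number no higher from compound 3 to compound 4 (the limit leaves the size open) is none beyond the scatter. Compound 4 is therefore estimated at 100000 nM, within 30000 nM to 300000 nM, and most likely the assay will again report only a limit.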

Compound 4, half-maximal inhibitory concentration: > 100000 nM
Compound 4 gave a limit, no number; the forecaster's own chance of this, stated with the estimate: 85%; the middle value sits exactly at the limit.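

Compound 4 gives > 100000 nM in this assay, which is a limit and not a number. Among the compounds shown here, no step to it from compound 3 or compound 2 can be read. The compounds shown leave open whether the amide group or the drawn configuration affects cytotoxicity at all.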